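This account rests on a few compounds, and the source may have more. Where it says the series, first, only, none or still open, it means among the compounds named here.

Among the compounds with values here, in a physicochemical assay for solubility, in phosphate buffer, at pH 7.4 (a higher number here means a more soluble compound, a lower number a less soluble compound), compound 1 (`CCNC(=O)Nc1nc2cc(-c3cncnc3)c(=O)n(C(C)C)c2s1`) gives 7000 nM while compound 2 (`CCNC(=O)Nc1nc2cc(-c3cncc(F)c3)c(=O)n(C(C)C)c2s1`) gives 73000 nM as the highest of the two numbers so far. Compound 3 (`CCNC(=O)Nc1nc2cc(-c3cncc(C#N)c3)c(=O)n(C(C)C)c2s1`) differs from compound 2 in one place (cyano in place of fluoro on an aromatic carbon) with cyano in place of fluoro on an aromatic carbon, so that 5-fluoropyridin-3-yl becomes 5-cyanopyridin-3-yl. Within the data shown here, one measured step bears on this, a 10-fold higher number from compound 1 to compound 2 (1.02 log units; beyond the scatter) in this assay and large, beyond the scatter. Among the measured compounds shown here, that step exchanged the ring itself rather than this substituent, and no measured pair holds the cyano group, so it offers a scale but no direction. For the measured compounds named here, with compound 2 at 73000 nM as the top number so far, a smaller, downward step is expected. The expected move is a 2.4-fold lower number from compound 2 to compound 3 (0.39 log units; beyond the scatter) with wide uncertainty. Compound 3 is estimated at 30000 nM (expected range 8000 nM to 90000 nM).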

Compound 3, solubility: < 5000 nM
Compound 3 ended at the assay's limit (the forecaster's own chance of this, stated with the estimate: 5%); middle value at least 6.0-fold (0.77 log units) away from the limit.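

Until now only an exchange of the ring itself had been seen, but in this assay a change of the substituent alone, two atoms from the ring nitrogen, also gives a large move: an at least 14-fold lower number from compound 2 to compound 3 (1.16 log units; beyond the scatter). The reading for compound 3 is a limit of the assay and not a number, so that step has a floor and no exact size: the limit of < 5000 nM in this assay, at which 1 of the 3 values shown sits. Measured against the pyrimidin-5-yl group, the same limit gives an at least 1.4-fold lower number from compound 1 to compound 3 (0.14 log units; that floor lies within the scatter), which sets no order between these two compounds.

Going by these compounds, how a methyl, a methoxy or an amine on this carbon would read remains open. With only fluoro and cyano at this position, a single pair of substituents carries the effect, and no trend across groups can be drawn from it.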